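The source may report more compounds than this note shows. Statements on the series, on what has been measured and on what is new or still open speak of the compounds shown alone.

Compound 1 `COc1ccn2ncc(/C=N/N(C)S(=O)(=O)c3cc([N+](=O)[O-])ccc3C)c2c1` was run in an assay on isolated protein for inhibition of phosphatidylinositol 4,5-bisphosphate 3-kinase catalytic subunit beta isoform (Homo sapiens), read by 33P incorporation, with a stated time of 60 min (a lower number here means a stronger inhibitor, a higher number a weaker inhibitor), and gives > 1000 nM, which is a limit of the assay rather than a number. Compound 2 `Cc1ccc([N+](=O)[O-])cc1S(=O)(=O)N(C)/N=C/c1cnn2cccc(Br)c12` in this assay gives > 1000 nM, again a limit and not a number. Both readings sit at the limit of > 1000 nM in this assay, at which 2 of the 2 values shown sit, so compound 1 stands on no measured number at all; on what is shown it sits at the limit with compound 2, and no order between the two can be drawn.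

Compound 3 `Cc1ccc([N+](=O)[O-])cc1S(=O)(=O)N(C)/N=C/c1cnn2ccc(Br)cc12` is the next compound for this assay. Set against compound 1 it differs in one place: bromo in place of methoxy on an aromatic carbon. Going by the values given here, no step between measured compounds exists, so the size of this change rests on nothing measured. With both compounds shown sitting at the limit, the expectation is of a step no larger than the scatter, and most likely another limit; the step expected from compound 1 to compound 3 is a step that the limit leaves unreadable from compound 1 to compound 3. Compound 3 is therefore estimated at 2000 nM, with a range from 700 nM to 10000 nM.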

Compound 3, half-maximal inhibitory concentration: 230 nM
Compound 3: middle estimate off by 8.7-fold (0.94 log units), on the high side; measured number below the stated range.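

In this assay, going by these compounds alone, bromo in place of methoxy on the aromatic carbon opposite the ring nitrogen gives the first reading that is a number and not a limit, with an at least 4.3-fold lower number from compound 1 to compound 3 (0.63 log units; beyond the scatter). That step has only a floor, and the series still holds a single number against two limits: the limit of > 1000 nM in this assay, at which 2 of the 3 values shown sit. Compound 2, with bromo on a different aromatic carbon of the core, gives > 1000 nM, which is a limit, so among the compounds shown bromo gives a numbered reading only at the place it holds in compound 3.

The compounds shown do not separate the loss of methoxy from the gain of bromo, since no compound carries plain hydrogen at this carbon, and the true size of the step stays open as long as compound 1 rests on a limit. Also open, from the compounds shown here alone, is how a chloro group, an amine or a longer ether chain such as ethoxy would read at this same carbon, and whether the nitro group on the other ring is needed for the reading of compound 3.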